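The source may hold more compounds than are shown below. What is called first, only, known or untested is meant among the compounds shown, and "the series" means these compounds.

Compound 1 `CCNC(=S)Nc1cccc(C(F)(F)F)c1` is tested in an ADME assay on BHK cells (Mesocricetus auratus) for cytotoxicity, read by MTT assay, with a stated time of 96 h (a higher number here means that more compound is tolerated, a lower number that less compound is tolerated), and reaches only a limit there, > 100000 nM. Among the measured compounds shown here, compound 2 `CCOC(=O)c1ccc(NC(=S)Nc2cccc(C(F)(F)F)c2)cc1` gives 50000 nM in this assay, which is the only plain number among the two values shown. Compound 3 `Fc1ccc(NC(=S)Nc2cccc(C(F)(F)F)c2)cc1` has not yet been measured in this assay; it differs from compound 2 by fluoro in place of ethoxycarbonyl on an aromatic carbon. For the measured compounds named here, no step between measured compounds is known here. A modest rise in tolerated concentration is expected, a 2.0-fold higher number from compound 2 to compound 3 (0.30 log units; within the scatter), beyond the usual scatter but not by much. Compound 3 is estimated to give about 100000 nM, with a likely range from 40000 nM to 250000 nM.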

Compound 3, half-maximal cytotoxic concentration: 26000 nM
Estimate against measurement, compound 3: 3.8-fold (0.59 log units) above; the measured number lies below the stated range.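

In this assay, fluoro in place of ethoxycarbonyl on this aromatic carbon gives a 1.9-fold lower number from compound 2 to compound 3 (0.28 log units; within the scatter) and so leaves these two groups indistinguishable here. Placing 4-fluorophenyl instead of ethyl on the amide-type nitrogen gives an at least 3.8-fold lower number from compound 1 to compound 3 (0.58 log units; beyond the scatter) and is the only change shown that clearly exceeds the scatter. As far as these compounds go, the true size of that step remains unknown, as it rests on a limit rather than a plain number: the limit of > 100000 nM in this assay, at which 1 of the 3 values shown sits. From the compounds shown here alone, whether an amine or a carboxylic acid on this aromatic carbon would separate from fluoro remains open. So does whether a longer chain on that nitrogen would fall closer to ethyl or to 4-fluorophenyl.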